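This account rests on a few compounds, and the source may have more. Where it says the series, first, only, none or still open, it means among the compounds named here.

Three compounds of the shared core have been run in an ADME assay on Vero cells (Chlorocebus sabaeus) for cytotoxicity, read by MTT assay, with a stated time of 48 h; on this read-out higher numbers stand for weaker inhibition and lower numbers for stronger inhibition. Compound 1 `COc1ccccc1C(=O)OC1CCC(CN2CCN(c3cc(=O)c4cc(C(F)(F)F)cc([N+](=O)[O-])c4s3)CC2)CC1` reaches only a limit of the assay there, > 64 ug/mL. Compound 2 `O=c1cc(N2CCN(CC3CCC(OS(=O)(=O)c4cccnc4)CC3)CC2)sc2c([N+](=O)[O-])cc(C(F)(F)F)cc12` likewise stops at a limit in this assay, > 64 ug/mL. Compound 3 `O=C(OC1CCC(CN2CCN(c3cc(=O)c4cc(C(F)(F)F)cc([N+](=O)[O-])c4s3)CC2)CC1)c1ccc(F)cc1` also gives no number in this assay but a limit, > 64 ug/mL. All three values sit at the limit of > 64 ug/mL in this assay, at which 3 of the 3 values shown sit, so the steps between them cannot be read: a step that the two limits leave unreadable from compound 1 to compound 2, a step that the two limits leave unreadable from compound 1 to compound 3 and a step that the two limits leave unreadable from compound 2 to compound 3 are each unreadable in size. Compound 2 thus stands at the limit, level with the other two as far as the numbers show.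

Compound 4 `O=c1cc(N2CCN(CC3CCC(OS(=O)(=O)c4ccccc4)CC3)CC2)sc2c([N+](=O)[O-])cc(C(F)(F)F)cc12` differs from compound 2 in a single place: phenyl in place of pyridin-3-yl on a sulfonyl sulfur. Among the measured compounds shown here, none of the measured steps has a readable size, and the group on the oxygen has been changed across the three measured compounds without any value moving off the limit. For compound 4 a value again at the limit in this assay is expected, so the expected step that the limit leaves unreadable from compound 2 to compound 4 is none beyond the scatter. The estimate for compound 4 is 100 ug/mL, with a range from 50 ug/mL to 250 ug/mL.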

Compound 4, half-maximal inhibitory concentration: > 64 ug/mL
Compound 4: a limit, no number; the forecaster's own chance of this, stated with the estimate: 85%; the middle value does not contradict the limit.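

Compound 4 gives only a limit, > 64 ug/mL, so its steps to and from compound 1, compound 2 and compound 3 cannot be read in this assay: the limit of > 64 ug/mL in this assay, at which 4 of the 4 values shown sit.

The compounds shown leave open where a numerical value lies for any of them, and whether the group on the oxygen affects it.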